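Swapping the Basic Amine Back Along a Longer Chain

The source may report more compounds than this note shows. Statements on the series, on what has been measured and on what is new or still open speak of the compounds shown alone.

Compound 3 `COc1c(OCCCN2CCN(C)CC2)cc(O)c2c(=O)cc(-c3ccccc3)oc12` gives 9900 nM in a functional assay on A549 cells (Homo sapiens) for cytotoxicity, read by MTT assay, with a stated time of 48 h (on this read-out higher numbers stand for weaker inhibition and lower numbers for stronger inhibition), the highest of the two numbers at hand. Compound 2 `CCN(CC)CCCOc1cc(O)c2c(=O)cc(-c3ccccc3)oc2c1OC` gives 1830 nM. Compound 1 `CN(C)CCCCOc1c(O)cc(O)c2c(=O)cc(-c3ccccc3)oc12` sits at the limit > 100000 nM, which is a limit and not a number. Compound 4 `CCN(CC)CCCCOc1cc(O)c2c(=O)cc(-c3ccccc3)oc2c1OC` differs from compound 3 by (diethylamino)methyl in place of 4-methylpiperazin-1-yl on a saturated chain carbon, three bonds along the chain from an oxygen on an aromatic ring. Among the compounds with values here, the one measured step that bears on this, a 5.4-fold higher number from compound 2 to compound 3 (0.73 log units; beyond the scatter), is the same exchange run the other way, so the number is expected to fall back by a similar amount, giving a 4.0-fold lower number from compound 3 to compound 4 (0.60 log units; beyond the scatter), although compound 4 also carries a longer chain than compound 2, which no measured step covers. Compound 4 is therefore estimated at 2500 nM, with a range from 900 nM to 7000 nM.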

Compound 4, half-maximal inhibitory concentration: 1000 nM
For compound 4 the middle estimate is 2.5-fold (0.40 log units) above the measured one; the measured number falls inside the stated range.
By their numbers in this assay, from the lowest: compounds 4 and 2 (each within the scatter of the next); then compound 3. At a limit, above all of these: compound 1.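

Replacing 3-(4-methylpiperazin-1-yl)propyl with 4-(diethylamino)butyl gives, in this assay, a 9.9-fold lower number from compound 3 to compound 4 (1.00 log units; beyond the scatter). The two compounds carrying a diethylamino end, on chains of different length, cannot be told apart: a 1.8-fold lower number from compound 2 to compound 4 (0.26 log units; within the scatter). Chain length therefore shows no separable effect with this amine, although compound 3 and compound 4 differ in both amine and chain.

Nothing measured here explains why compound 3 gives the higher number. From the compounds shown here alone, whether a morpholine or a pyrrolidine on the butyl chain, or a still longer chain carrying diethylamino, would read like compound 4 remains open.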